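Trimming a Methyl: From Compound 2 to Compound 4

The compounds below may be only part of what the source reports. "The series", "measured", "known", "first", "only" and "open" are said of these compounds alone.

Compound 1 `O=C(O)[C@@H]1CCCN1C(=O)CN(c1nc(Cl)nc2[nH]cnc12)C1CC1` gives 34.9%
Compound 2 `CC[C@H](C)[C@H](NC(=O)CN(c1ncnc2c1ncn2C1CCCCO1)C1CC1)C(=O)OCc1ccccc1` gives 27.4%
Compound 3 `CC(C)C[C@H](NC(=O)CN(c1nc(Cl)nc2[nH]cnc12)C1CC1)C(=O)OCc1ccccc1` gives 27.3%

Of the compounds shown here, three have been measured in a functional assay on the whole organism (Tail, strain ICR) with Mus musculus as the target, in the tail flick test, with a stated time of 60 min, at a dose of 25 umol/kg by the oral route; a higher number here means a stronger effect of the compound at the dose given, a lower number a weaker effect. Compound 2 stands second highest of the three numbers. Its nearest neighbour is compound 3, whose value lies a little lower, within the scatter of repeated measurement; its furthest is compound 1, whose value lies higher, yet also within the scatter. Among the measured compounds shown here, the three measured values therefore cannot be put in a reliable order, and no pair of them differs in a single place, so no measured step is available to guide the next case.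

Compound 4 `CC(C)[C@H](NC(=O)CN(c1ncnc2c1ncn2C1CCCCO1)C1CC1)C(=O)OCc1ccccc1` is the next compound to be measured in this assay. It differs from compound 2 in one place: hydrogen in place of methyl on a saturated chain carbon, three bonds along the chain from an amide-type nitrogen and a carbonyl carbon. For the measured compounds named here, nothing among the measured compounds isolates the effect of this change. A shift of no more than the scatter is expected, and the step from compound 2 to compound 4 is estimated as a number 0.4 percentage points lower from compound 2 to compound 4 (within the scatter). For compound 4 the expected value in this assay is 27%, with a range from 15% to 40%.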

Compound 4, a percentage reported as activity, at one dose (the size of the read-out at that dose, not a potency): 34.9%
For compound 4 the middle estimate is 7.9 percentage points below the measured one; the measured number falls inside the stated range.
By their numbers in this assay, from the lowest: compounds 3, 2, 1 and 4 (each within the scatter of the next).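

In this assay, among the compounds shown here, cutting sec-butyl to isopropyl on this saturated chain carbon gives a number 7.5 percentage points higher from compound 2 to compound 4 (within the scatter) and so provides the first measured step in which only one place changes. It shows that, at this dose and time, removing this single methyl, with no ring, hydrogen-bond donor, hydrogen-bond acceptor or net charge involved, does not carry the read-out beyond the usual scatter, so the two side chains cannot be put in order here. No measured information given here bears on what might lie behind the size of this step.

As far as these compounds go, what a larger departure from these two branched chains would do remains open: a longer chain, a phenyl ring, an amine or a carboxylic acid at this carbon could each show whether the position has any real influence on the read-out. A single step within the scatter also leaves open whether the same exchange would give a comparable result on a different core, or at another dose or time in this assay.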